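One Fluorine Removed: From Compound 3 to Compound 4

The source may report more compounds than this note shows. Statements on the series, on what has been measured and on what is new or still open speak of the compounds shown alone.

Three compounds share a core and differ only in the group on an oxygen on an aromatic ring. Compound 1 `CC(C)(C)Oc1ccc([C@@H](CC(=O)O)NC(=O)[C@@H]2CCCN2S(=O)(=O)c2cc(Cl)cc(Cl)c2)cc1` carries a tert-butyl there, and in an assay on RPMI-8866 cells for inhibition of integrin alpha-4/beta-1 (Homo sapiens) (a higher number here means a weaker inhibitor, a lower number a stronger inhibitor), compound 1 gives 0.53 nM. Compound 2 `O=C(O)C[C@@H](NC(=O)[C@@H]1CCN1S(=O)(=O)c1cc(Cl)cc(Cl)c1)c1ccc(OC2CCCC2)cc1` carries a cyclopentyl, and compound 2 gives 0.5 nM. Compound 3 `O=C(O)C[C@@H](NC(=O)[C@@H]1CCN1S(=O)(=O)c1cc(Cl)cc(Cl)c1)c1ccc(OC(F)F)cc1` carries a difluoromethyl, and compound 3 gives 1.3 nM, the highest of the three numbers; the step of a 2.6-fold higher number from compound 2 to compound 3 (0.41 log units; beyond the scatter) was modest but beyond the scatter, and compound 3 also stands beyond the scatter from compound 1.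

Compound 4 `O=C(O)C[C@@H](NC(=O)[C@@H]1CCN1S(=O)(=O)c1cc(Cl)cc(Cl)c1)c1ccc(OCF)cc1` differs from compound 3 by hydrogen in place of fluoro on a saturated chain carbon bound to a fluorine atom and an oxygen on an aromatic ring. Within the data shown here, no measured step exchanges a single fluorine for hydrogen; the one measured step, a 2.6-fold higher number from compound 2 to compound 3 (0.41 log units; beyond the scatter), swaps a whole ring for a difluoromethyl and so bears only loosely on this smaller change. The groups on that oxygen have so far moved the number only modestly, so taking away one fluorine atom is expected to move it little. The expected step of a 1.1-fold lower number from compound 3 to compound 4 (0.03 log units; within the scatter) for compound 4 lies within the scatter. Compound 4 is estimated at 1.2 nM, with a range from 0.5 nM to 3 nM.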

Compound 4, half-maximal inhibitory concentration: 0.72 nM
Compound 4: the middle estimate sits 1.7-fold (0.22 log units) above what was measured; the range from low to high includes it.
By their numbers in this assay, from the lowest: compounds 2, 1, 4 and 3 (each within the scatter of the next, the first and the last beyond it).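

In this assay, among these compounds, the change from difluoromethyl to fluoromethyl gives the only direct reading of a single fluorine exchanged for hydrogen on this carbon, and the step of a 1.8-fold lower number from compound 3 to compound 4 (0.26 log units; within the scatter) does not separate the two groups. The step of a 1.4-fold higher number from compound 2 to compound 4 (0.16 log units; within the scatter) does not separate fluoromethyl from cyclopentyl either, even though the step of a 2.6-fold higher number from compound 2 to compound 3 (0.41 log units; beyond the scatter) does separate difluoromethyl from cyclopentyl, so compound 4 cannot be placed firmly with either neighbour. Nothing given here explains how these groups compare in this assay.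

The compounds shown leave open how a plain methyl or a trifluoromethyl on this oxygen would compare with fluoromethyl and difluoromethyl, and those two groups would extend the fluorine series in both directions. Also open, from the compounds shown here alone, is whether a longer chain carrying fluorine, or an amine in place of the fluorinated group, would stay this close to the values seen so far.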